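The source may report more compounds than this note shows. Statements on the series, on what has been measured and on what is new or still open speak of the compounds shown alone.

Measured so far in an ADME assay on HeLa cells (Homo sapiens) for cytotoxicity, read by microscopy; on this read-out lower numbers stand for higher toxicity in this test and higher numbers for lower toxicity in this test:

- compound 1 `CSc1nc(NCCCNc2ccnc3cc(Cl)ccc23)c(C#N)c(-c2ccccc2)n1`: 100000 nM
- compound 2 `CSc1nc(NCCCCNc2ccnc3cc(Cl)ccc23)c(C#N)c(-c2cccc([N+](=O)[O-])c2)n1`: 100000 nM
- compound 3 `COc1ccc(-c2nc(SC)nc(NCCCCNc3ccnc4cc(Cl)ccc34)c2C#N)cc1OC`: 100000 nM

Compound 2 stands level with compounds 1 and 3 in this assay; all three show the same minimum cytotoxic concentration at the digits given, within the scatter. Compound 4 `COc1cc(-c2nc(SC)nc(NCCCCNc3ccnc4cc(Cl)ccc34)c2C#N)cc(OC)c1OC` has not yet been measured. It differs from compound 2 in one place: 3,4,5-trimethoxyphenyl in place of 3-nitrophenyl on an aromatic carbon. For the measured compounds named here, one measured step bears on this: an aryl exchange at the same place, no change at the digits printed from compound 2 to compound 3 (within the scatter), which left the read-out unchanged within the scatter. On that basis no step beyond the scatter is expected for compound 4, so no change at the digits printed from compound 2 to compound 4 (within the scatter) is the expected outcome. The estimate for compound 4 is 100000 nM, with a range from 50000 nM to 100000 nM.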

Compound 4, minimum cytotoxic concentration: 20000 nM
The estimate for compound 4 lay 5.0-fold (0.70 log units) above the measured number; measured number outside the range, below it.
By their numbers in this assay, from the lowest: compound 4; then compounds 1, 2 and 3 (each within the scatter of the next).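

In this assay, the aryl group at this position can change the read-out, although no change at the digits printed from compound 2 to compound 3 (within the scatter) gave no sign of this. Replacing 3-nitrophenyl with 3,4,5-trimethoxyphenyl gives a 5.0-fold lower number from compound 2 to compound 4 (0.70 log units; beyond the scatter), and the closer pair, with methoxy in place of hydrogen, gives a 5.0-fold lower number from compound 3 to compound 4 (0.70 log units; beyond the scatter), so this one added methoxy is enough to bring the lower number, which stands for higher toxicity in this test.

Going by these compounds, whether an amine or a carboxylic acid on this phenyl ring, or a longer chain linking the two amines, would shift the read-out remains open. No measurement at hand accounts for the step.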